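The source may hold more compounds than are shown below. What is called first, only, known or untested is meant among the compounds shown, and "the series" means these compounds.

Working notes on the series. In a functional assay on MOLT-4 cells (Homo sapiens) for inhibition, read by MTT assay, with a stated time of 48 h (on this read-out higher numbers stand for weaker inhibition and lower numbers for stronger inhibition), compound 1 (`O=C(/C=C/c1cn(Cc2ccccc2)c2ccccc12)CC(=O)C(=O)O`) gives 15000 nM and compound 2 (`O=C(/C=C/c1cn(Cc2ccc(Cl)cc2)c2ccccc12)CC(=O)C(=O)O`) gives 19000 nM. Within the data shown here, compound 2 therefore stands within the scatter of compound 1, the only other measured compound, and no order can be read between the two.

Next is compound 3 (`CN(C)C(=O)Cn1cc(/C=C/C(=O)CC(=O)C(=O)O)c2ccccc21`), with this difference: dimethylcarbamoyl in place of 4-chlorophenyl on a saturated chain carbon bound to an aromatic nitrogen. In words, this is dimethylcarbamoyl in place of 4-chlorophenyl on a saturated chain carbon bound to an aromatic nitrogen.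

Among the measured compounds shown here, only one measured step is available, a 1.3-fold higher number from compound 1 to compound 2 (0.10 log units; within the scatter), with chloro in place of hydrogen on an aromatic carbon. It bears on the new change only loosely, since it alters the aromatic ring that leaves in compound 3 but does not replace that ring. For the measured compounds named here, no measured step replaces the ring, so the data give no direction for this change.

Taking compound 2 at 19000 nM as the anchor, no shift beyond the scatter is expected in this assay. The expected change is a 1.3-fold higher number from compound 2 to compound 3 (0.12 log units; within the scatter). For compound 3 the estimated value is 25000 nM, with an expected range of 9000 nM to 70000 nM.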

Compound 3, half-maximal inhibitory concentration: > 40000 nM
Compound 3: only a limit was reported; the forecaster's own chance of this, stated with the estimate: 15%; middle value at least 1.6-fold (0.20 log units) away from the limit.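

Among these compounds, replacing the aromatic ring on this saturated chain carbon bound to an aromatic nitrogen is the first change to move the read-out beyond the scatter in this assay: dimethylcarbamoyl in place of 4-chlorophenyl gives an at least 2.1-fold higher number from compound 2 to compound 3 (0.32 log units; beyond the scatter), and dimethylcarbamoyl in place of phenyl gives an at least 2.6-fold higher number from compound 1 to compound 3 (0.42 log units; beyond the scatter). Compound 3 is reported only as a limit and not as a number: the limit of > 40000 nM in this assay, at which 1 of the 3 values shown sits. Read together with the chloro step, which stays within the scatter, the three compounds show that inhibition at this position held up when the aromatic ring gained a chloro group but weakened when dimethylcarbamoyl took the place of the ring.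

The compounds shown do not separate the departure of the aromatic ring from the arrival of dimethylcarbamoyl, a question that a cyclohexyl group or a plain alkyl chain on the same carbon would address. On these data alone, whether an amine, a carboxylic acid or a longer chain at this place would fare any differently from dimethylcarbamoyl also stays open.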